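The compounds below may be only part of what the source reports. "The series", "measured", "known", "first", "only" and "open" are said of these compounds alone.

Measured in an in vitro functional assay on HEK285-7 cells for antagonist activity at prostaglandin D2 receptor 2 (Homo sapiens), read by BRET and beta-arrestin recruitment; a lower number here means a stronger inhibitor, a higher number a weaker inhibitor:
compound 1 `O=C(O)Cc1sc(C(c2ccccc2)c2ccccc2)nc1-c1ccccc1` gives 370 nM.
compound 2 `Nc1nc(-c2ccc(Cl)cc2)c(CC(=O)O)s1` gives > 100000 nM, which is a limit of the assay and not a number.
compound 3 `O=C(O)Cc1sc(C(c2ccc(F)cc2)c2ccc(F)cc2)nc1-c1ccnc(N2CCC2)c1` gives > 100000 nM, again only a limit of the assay.

Compound 3 therefore stands at the limit of > 100000 nM in this assay, at which 2 of the 3 values shown sit, with no measured number of its own. Compound 4 `NS(=O)(=O)c1cccc(-c2nc(C(c3ccc(F)cc3)c3ccc(F)cc3)sc2CC(=O)O)c1` differs from compound 3 in one place: 3-sulfamoylphenyl in place of 2-(azetidin-1-yl)pyridin-4-yl on an aromatic carbon. Within the data shown here, no step between measured compounds covers this change, so its size is open. Of the measured compounds, the one closest in build to compound 4 is compound 1, which gives 370 nM. For compound 4 a step back toward a measurable value is expected, an at least 33-fold lower number from compound 3 to compound 4 (1.52 log units; beyond the scatter). Compound 4 is estimated at 3000 nM, within a wide range from 300 nM to 50000 nM.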

Compound 4, half-maximal inhibitory concentration: 710 nM
Compound 4: middle estimate off by 4.2-fold (0.63 log units), on the high side; low and high end bracket the measured number.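

Compound 3 gives > 100000 nM, which is a limit of the assay and not a number. Putting 3-sulfamoylphenyl in place of 2-(azetidin-1-yl)pyridin-4-yl on the carbon next to the ring nitrogen gives an at least 140-fold lower number from compound 3 to compound 4 (2.14 log units; beyond the scatter), so the group at this position alone can decide whether a measurable value appears. One end of this step is a limit, so its true size stays unknown: the limit of > 100000 nM in this assay, at which 2 of the 4 values shown sit.

The change replaces the whole group, so the share of the sulfamoyl group and of the ring swap cannot be separated. On these data alone, what a carboxylic acid or an amine in place of the sulfamoyl group would give remains open.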